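Homologating the thiazole ester: from compound 3 to compound 4

A few compounds are considered here, and "the series" means these few. Any claim that something is new, unique, unknown or untested is made for them only; others in the source may bear on it.

Measured compounds:
compound 1 `CC1(C)CC(NC(=O)c2ccc(Nc3ncc([N+](=O)[O-])c(NC4CCCC4)n3)cc2)CC(C)(C)N1[O]` 33200 nM
compound 2 `CCN1CCN(c2nc(Nc3ccc(C(=O)NC4CC(C)(C)N([O])C(C)(C)C4)cc3)ncc2[N+](=O)[O-])CC1` 1960 nM
compound 3 `CCOC(=O)c1csc(Nc2nc(Nc3ccc(C(=O)NC4CC(C)(C)N([O])C(C)(C)C4)cc3)ncc2[N+](=O)[O-])n1` 740 nM

In a functional assay on A549 cells (Homo sapiens) for antiproliferative activity, read by MTT assay, with a stated time of 48 h (on this read-out lower numbers stand for stronger inhibition and higher numbers for weaker inhibition), compound 3 gives 740 nM, the lowest of the three numbers. The nearest is compound 2 at 1960 nM, and the step of a 2.6-fold lower number from compound 2 to compound 3 (0.42 log units; beyond the scatter) is modest; the furthest is compound 1 at 33200 nM, and the step of a 45-fold lower number from compound 1 to compound 3 (1.65 log units; beyond the scatter) is large. The other recorded change, a 17-fold lower number from compound 1 to compound 2 (1.23 log units; beyond the scatter), is also large.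

Compound 4 `CCOC(=O)Cc1csc(Nc2nc(Nc3ccc(C(=O)NC4CC(C)(C)N([O])C(C)(C)C4)cc3)ncc2[N+](=O)[O-])n1` differs from compound 3 in one place: (ethoxycarbonyl)methyl in place of ethoxycarbonyl on an aromatic carbon. Every measured step concerns the group carried by the shared core, not a substituent on the thiazole ring itself, so none of them bears directly on this change. The three steps only show that the group on that side of the core can move the read-out a great deal, while the thiazole-bearing compound 3 is the best of those seen. Within the data shown here, with no comparable step recorded, the expected change from compound 3 to compound 4 in this assay is a 1.2-fold higher number from compound 3 to compound 4 (0.09 log units; within the scatter), that is, none beyond the scatter. Compound 4 is therefore estimated at 900 nM in this assay, with a range from 300 nM to 3000 nM.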

Compound 4, half-maximal inhibitory concentration: 1040 nM
Beside the measured number, compound 4's estimate is 1.2-fold (0.06 log units) below it, within the range that was stated.
By their numbers in this assay, from the lowest: compounds 3, 4 and 2 (each within the scatter of the next, the first and the last beyond it); then compound 1.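

In this assay, putting (ethoxycarbonyl)methyl in place of ethoxycarbonyl on this aromatic carbon, next to the ring nitrogen of the five-membered aromatic ring, gives a 1.4-fold higher number from compound 3 to compound 4 (0.15 log units; within the scatter) and so shows that this change at this position leaves the read-out within the usual scatter. Compound 4 also keeps the large separation from the cyclopentylamino compound, with a 32-fold lower number from compound 1 to compound 4 (1.50 log units; beyond the scatter) as the printed step, while a 1.9-fold lower number from compound 2 to compound 4 (0.28 log units; within the scatter) places it within the scatter of the ethylpiperazine compound, a separation that compound 3 alone had shown as beyond the scatter. No measurement is available that accounts for this result.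

The compounds shown leave open whether the ester is needed on this aromatic carbon at all, a question that a carboxylic acid, a primary amide or a simple methyl group there would address. They also leave open how far the chain can be extended, as with a longer chain carrying the same ethyl ester, and whether the read-out would then stay within the scatter of compound 3 or move beyond it.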